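Cyano for trifluoromethyl-thiazolyl: expected cytotoxicity of compound 4

The source may report more compounds than this note shows. Statements on the series, on what has been measured and on what is new or still open speak of the compounds shown alone.

Three compounds share one core and differ in the group on a saturated ring carbon of the five-membered non-aromatic ring. Compound 1 `O=C1OC(c2ccccc2)CN1c1cnn2c1CN(C(=O)Nc1cc(F)c(F)c(F)c1)C(C1CC1)C2` gives 7410 nM in a toxicity assay on HepG2 2.2.15 cells (Homo sapiens) for cytotoxicity, read by CellTiter-Glo; on this read-out lower numbers stand for higher toxicity in this test and higher numbers for lower toxicity in this test. Compound 2 `O=C1CC(c2ccc(F)cn2)CN1c1cnn2c1CN(C(=O)Nc1cc(F)c(F)c(F)c1)C(C1CC1)C2` gives 38500 nM in that assay, and compound 3 `O=C1CC(c2cnc(C(F)(F)F)s2)CN1c1cnn2c1CN(C(=O)Nc1cc(F)c(F)c(F)c1)C(C1CC1)C2` gives 38500 nM. Compound 3 thus stands level with compound 2 at the digits shown, the two together the highest numbers of the three, while compound 1 sits lower by a gap beyond the scatter. Among the measured compounds shown here, the one step between measured neighbours, no change at the digits printed from compound 2 to compound 3 (within the scatter), swaps one aromatic ring for another and leaves the number unchanged.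

Compound 4 `N#CC1CC(=O)N(c2cnn3c2CN(C(=O)Nc2cc(F)c(F)c(F)c2)C(C2CC2)C3)C1` is not yet measured. Its difference from compound 3 is cyano in place of 2-(trifluoromethyl)-1,3-thiazol-5-yl on a saturated ring carbon. For the measured compounds named here, no measured step replaces an aromatic ring with a small group such as cyano, so the only guide is the indifference of the read-out to the ring swap from compound 2 to compound 3. On that basis he expects compound 4 to show no step beyond the scatter in this assay, estimating a 1.3-fold lower number from compound 3 to compound 4 (0.11 log units; within the scatter). His estimate for compound 4 is therefore 30000 nM, within a range from 10000 nM to 70000 nM.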

Compound 4, half-maximal cytotoxic concentration: > 200000 nM
Compound 4: only a limit was reported (the forecaster's own chance of this, stated with the estimate: 30%); middle value at least 6.6-fold (0.82 log units) away from the limit.
By their numbers in this assay, from the lowest: compound 1; then compounds 2 and 3 (each within the scatter of the next). At a limit, above all of these: compound 4.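

In this assay compound 4 stands at a limit and not at a number: the limit of > 200000 nM in this assay, at which 1 of the 4 values shown sits. The saturated ring carbon had shown no response to one aromatic ring replacing another, but it is not indifferent to every change, as cyano in place of 2-(trifluoromethyl)-1,3-thiazol-5-yl brings an at least 5.1-fold higher number from compound 3 to compound 4 (0.71 log units; beyond the scatter), and cyano in place of 5-fluoropyridin-2-yl brings an at least 5.1-fold higher number from compound 2 to compound 4 (0.71 log units; beyond the scatter). Replacing the whole 2-oxo-5-phenyl-1,3-oxazolidin-3-yl group on the aromatic carbon with 4-cyano-2-oxopyrrolidin-1-yl brings a large step, an at least 26-fold higher number from compound 1 to compound 4 (1.43 log units; beyond the scatter), though this swap alters the ring as well as its substituent, so it does not isolate cyano.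

The compounds shown leave open whether the rise belongs to cyano itself or would follow from removing the aromatic ring in favour of another small group, such as a methyl, a hydroxymethyl or a carboxylic acid on that saturated ring carbon. They also leave open how far the true value of compound 4 lies past its limit, and so the full size of all three steps.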